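The source may report more compounds than this note shows. Statements on the series, on what has been measured and on what is new or still open speak of the compounds shown alone.

Compound 1 `COc1ccc(CN(C(=O)CSc2nc3ccccc3s2)c2cc(OC)c(OC)c(OC)c2)cc1C`: 34300 nM
Compound 2 `COc1cc(N(Cc2ccc(C)cc2)C(=O)CSc2nc3ccccc3s2)cc(OC)c1OC`: > 80000 nM (a limit, not a number)

In a functional assay on PC-3 cells (Homo sapiens) for antiproliferative activity, read by MTT assay, with a stated time of 48 h (a higher number here means a weaker inhibitor, a lower number a stronger inhibitor), compound 2 stands at the limit of > 80000 nM in this assay, at which 1 of the 2 values shown sits. Compound 3 `COc1ccc(CN(C(=O)CSc2nc3ccccc3s2)c2cc(OC)c(OC)c(OC)c2)cc1N=[N+]=[N-]` carries 3-azido-4-methoxyphenyl in place of 4-methylphenyl on a saturated chain carbon bound to an amide-type nitrogen. For the measured compounds named here, the only measured step that bears on this is an at least 2.3-fold higher number from compound 1 to compound 2 (0.36 log units; beyond the scatter), which took 4-methylphenyl in place of 4-methoxy-3-methylphenyl. Going by the values given here, compound 3 regains the methoxy of compound 1, so a number near the 34300 nM of compound 1 is expected, although no measured compound carries an azido group. The expected change is an at least 2.2-fold lower number from compound 2 to compound 3 (0.35 log units; beyond the scatter), a modest step towards stronger inhibition. The estimate for compound 3 is 35000 nM, with a range from 12000 nM to 80000 nM.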

Compound 3, half-maximal inhibitory concentration: 14400 nM
Estimate against measurement, compound 3: 2.4-fold (0.39 log units) above; measured number inside the range.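

In this assay, azido in place of methyl on an aromatic carbon gives a 2.4-fold lower number from compound 1 to compound 3 (0.38 log units; beyond the scatter), so a change on this ring can now strengthen inhibition relative to compound 1, not only weaken it. The wider change from 4-methylbenzyl to 3-azido-4-methoxybenzyl gives an at least 5.5-fold lower number from compound 2 to compound 3 (0.74 log units; beyond the scatter), and its size is open-ended, as compound 2 has only a limit, not a number: the limit of > 80000 nM in this assay, at which 1 of the 3 values shown sits.

The compounds shown leave open whether azido is special here, or whether an amine or a chlorine atom in its place would serve equally well.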